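A few compounds are considered here, and "the series" means these few. Any claim that something is new, unique, unknown or untested is made for them only; others in the source may bear on it.

Compound 2 `CC[C@H](C)Nc1nc(Cl)nc(N[C@@H](C)c2ccccc2)n1` carries the highest number of the three in an ADME assay on the whole organism for inhibition, with Echinochloa crus-galli var. formosensis as the target, with a stated time of 4 days (on this read-out lower numbers stand for stronger inhibition and higher numbers for weaker inhibition), giving 14100 nM. Compound 1 `C[C@H](Nc1nc(Cl)nc(NC(C)(C)C)n1)c1ccccc1` gives 7410 nM and compound 3 `CCNc1nc(Cl)nc(NC(C)c2ccccc2)n1` gives 9770 nM; both lie within the scatter of compound 2. Going by the values given here, the only single-place step so far, a 1.9-fold higher number from compound 1 to compound 2 (0.28 log units; within the scatter), swaps one alkyl on the ring nitrogen and stays within the scatter.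

Compound 4 `CC[C@@H](C)Nc1nc(Cl)nc(N[C@H](C)c2ccccc2)n1` differs from compound 2 thus: the two compounds have the same atoms and bonds and differ only in configuration as drawn: 2 of 2 stereo elements differ (all stereocentres are inverted: mirror images); a stereocentre at a saturated chain carbon is drawn S in compound 2 and R in compound 4; a stereocentre at a saturated chain carbon is drawn S in compound 2 and R in compound 4. Among the compounds with values here, no measured pair compares mirror images, so nothing here bears directly on this change; compound 3, drawn without configuration at its chain carbon, sits near compound 2. With no guide to direction, compound 4 is expected to give 11000 nM, between 3000 nM and 40000 nM, a step of a 1.3-fold lower number from compound 2 to compound 4 (0.11 log units; within the scatter) that is not expected to exceed the scatter.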

Compound 4, half-maximal inhibitory concentration: 4570 nM
For compound 4 the middle estimate is 2.4-fold (0.38 log units) above the measured one; low and high end bracket the measured number.
By their numbers in this assay, from the lowest: compounds 4, 1, 3 and 2 (each within the scatter of the next, the first and the last beyond it).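

In this assay, going by these compounds alone, inverting both stereocentres gives a 3.1-fold lower number from compound 2 to compound 4 (0.49 log units; beyond the scatter), the only step so far beyond the scatter, whereas the alkyl swap on the nitrogen stayed within it. The shift can be assigned to configuration alone because of what the pair shares: the fact that compounds 2 and 4 differ only in the configuration as drawn. Configuration at these chain carbons therefore counts in this series, with the R,R drawing giving the lower number.

Which of the two stereocentres carries the step stays open. Also open, as far as these compounds go, is whether the same preference holds with a longer chain in place of sec-butyl, or with a methoxy group in place of the chlorine.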